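From Fluoro to Chloro: Estimating Compound 3

The compounds below may be only part of what the source reports. "The series", "measured", "known", "first", "only" and "open" are said of these compounds alone.

- Compound 1 `C=C(c1cccc2ccccc12)C1CCC2(CC1)COC(Nc1ccc(Cl)cc1)OO2` gives 6.15
- Compound 2 `C=C(c1ccc2ccccc2c1)C1CCC2(CC1)COC(Nc1ccc(F)cc1)OO2` gives 5.75

Among the measured compounds shown here, both numbers come from a physicochemical assay for lipophilicity (on this read-out higher numbers stand for higher lipophilicity and lower numbers for lower lipophilicity), and are the only measurements so far. Compound 2 has the lower of the two numbers, and the gap up to compound 1 is beyond the usual scatter of repeated measurements. For the measured compounds named here, these two compounds do not differ in just one place, so no clean measured step is available as a guide.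

Compound 3 `C=C(c1ccc2ccccc2c1)C1CCC2(CC1)COC(Nc1ccc(Cl)cc1)OO2` has not yet been measured. It departs from compound 2 in a single place: chloro in place of fluoro on an aromatic carbon (chloro in place of fluoro on an aromatic carbon, para to a large group). Compound 1 carries the 4-chlorophenyl group as well and gives 6.15 in this assay, so compound 3 is expected to land close to that number. The expected change is an upward a number 0.45 log units higher from compound 2 to compound 3 (beyond the scatter) and is estimated to lie beyond the scatter. With so few measurements, this remains a rough expectation. Compound 3 is expected at 6.2 with a likely range from 5.95 to 6.45 on this estimate.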

Compound 3, partition coefficient: 6.15
Compound 3: the middle estimate sits 0.05 log units above what was measured; the measured number falls inside the stated range.
By their numbers in this assay, from the lowest: compound 2; then compounds 1 and 3 (each within the scatter of the next).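

In this assay, among the compounds shown here, chloro in place of fluoro on an aromatic carbon, para to a large group, gives a number 0.40 log units higher from compound 2 to compound 3 (beyond the scatter) with nothing else in the molecule altered, which is the first reading of this change on its own, as the earlier pair differed in more than one place. Naphthalen-2-yl in place of naphthalen-1-yl on a double-bonded chain carbon bound to a saturated ring carbon gives no change at the digits printed from compound 1 to compound 3 (within the scatter) in compounds that both carry the 4-chlorophenyl group, so this second change, unlike the halogen change, shows no step beyond the scatter in this pair. No supporting measurement is available to explain the size of either step.

With only fluoro and chloro shown at this position, a single pair cannot say how a bromo, methoxy or nitrile group would compare there. As far as these compounds go, it also stays open whether the two naphthalenyl groups would still match when the 4-fluorophenyl group takes the place of the 4-chlorophenyl group, or when an amine or a carboxylic acid sits on that ring.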